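The source may report more compounds than this note shows. Statements on the series, on what has been measured and on what is new or still open speak of the compounds shown alone.

Compound 3 `CCCCOc1ccc(CNC(=O)Oc2cccc(Cl)c2)cc1` gives the lowest number of the three compounds examined in an assay on H4 cells for inhibition of Fatty-acid amide hydrolase 1 (Homo sapiens) (a higher number here means a weaker inhibitor, a lower number a stronger inhibitor), at 12 nM; compound 2 `CCCCOc1ccc(CNC(=O)Oc2cccc(C(F)(F)F)c2)cc1` gives 40 nM and compound 1 `CCCCOc1ccc(NC(=O)Oc2ccccc2F)cc1` gives 340 nM. Compound 4 `CCCCOc1ccc(CNC(=O)Oc2ccccc2F)cc1` differs from compound 3 by 2-fluorophenyl in place of 3-chlorophenyl on an oxygen next to a carbonyl group. For the measured compounds named here, the only step that bears on a change of the aryl carbamate is the one from compound 2 to compound 3, a 3.3-fold lower number from compound 2 to compound 3 (0.52 log units; beyond the scatter), a modest shift for a single substituent swap; compound 1 also carries the 2-fluorophenyl group, but on a different core, so its value is only a loose hint. Compound 4 is therefore expected to give a somewhat higher number, a 5.0-fold higher number from compound 3 to compound 4 (0.70 log units; beyond the scatter), with an estimate of 60 nM and a range from 15 nM to 250 nM.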

Compound 4, half-maximal inhibitory concentration: 9.2 nM
Beside the measured number, compound 4's estimate is 6.5-fold (0.81 log units) above it, and the stated range ends above it.
By their numbers in this assay, from the lowest: compounds 4 and 3 (each within the scatter of the next); then compound 2; then compound 1.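

In this assay, the change from 3-chlorophenyl to 2-fluorophenyl on an oxygen next to a carbonyl group gives a 1.3-fold lower number from compound 3 to compound 4 (0.12 log units; within the scatter), so the two groups cannot be told apart here. The earlier step, a 3.3-fold lower number from compound 2 to compound 3 (0.52 log units; beyond the scatter), showed that this aryl group can matter; this one shows that its halogen and ring position can change together with no shift beyond the scatter. Nothing available explains this result.
Going by these compounds, the separate contributions of the halogen and its ring position remain open, because both differ in this single step. Also open, on these data alone, is how an amine or a carboxylic acid on this aryl ring would fare.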